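The compounds below may be only part of what the source reports. "The series", "measured", "known", "first", "only" and "open" are said of these compounds alone.

Compound 1 `Nc1cc(N)c2nc(-c3ccccc3)c(Oc3ccc(Cl)c(Cl)c3)nc2c1` gives < 100000 nM in a functional assay on CAKI-1 cells (Homo sapiens) for inhibition, read by sulforhodamine B assay, with a stated time of 48 h (on this read-out lower numbers stand for stronger inhibition of growth and higher numbers for weaker inhibition of growth), which is a limit of the assay and not a number. Compound 2 `COc1ccc(Sc2nc3cc(N)cc(N)c3nc2-c2ccccc2)cc1` gives 52500 nM in this assay. Compound 3 `Nc1cc(N)c2nc(-c3ccccc3)c(Sc3ccc(Cl)c(Cl)c3)nc2c1` gives 37200 nM in this assay.

Of the two numbers shown, compound 3 has the lower one, yet the step of a 1.4-fold lower number from compound 2 to compound 3 (0.15 log units; within the scatter) lies within the scatter, so no order between the two can be claimed. For compound 1 only the limit of < 100000 nM in this assay, at which 1 of the 3 values shown sits, is shown.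

The next compound, compound 4 `Nc1cc(N)c2nc(-c3ccccc3)c(Oc3ccc(F)cc3)nc2c1`, differs from compound 3 in one place: 4-fluorophenoxy in place of (3,4-dichlorophenyl)sulfanyl on an aromatic carbon. For the measured compounds named here, two measured steps touch this change. The step that the limit leaves unreadable from compound 1 to compound 3 exchanges an oxygen bridge for a sulfur bridge, but its size cannot be read. The step of a 1.4-fold lower number from compound 2 to compound 3 (0.15 log units; within the scatter) exchanges the aryl group on the sulfur and stays within the scatter. Nothing shown points to a step beyond the scatter, so the expected change is small, a 1.2-fold higher number from compound 3 to compound 4 (0.08 log units; within the scatter). Compound 4 is estimated at 45000 nM, with a range from 15000 nM to 130000 nM.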

Compound 4, concentration for total growth inhibition: 24500 nM
The estimate for compound 4 lay 1.8-fold (0.26 log units) above the measured number; measured number inside the range.
By their numbers in this assay, from the lowest: compounds 4, 3 and 2 (each within the scatter of the next, the first and the last beyond it).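

Replacing (3,4-dichlorophenyl)sulfanyl with 4-fluorophenoxy on the aromatic carbon next to the ring nitrogen gives a 1.5-fold lower number from compound 3 to compound 4 (0.18 log units; within the scatter), so this exchange shows no clear change in this assay. Replacing (4-methoxyphenyl)sulfanyl with the same group gives a 2.1-fold lower number from compound 2 to compound 4 (0.33 log units; beyond the scatter), a modest step and the only one of the two beyond the scatter. Compound 1 stands at a limit of the assay, so its step to compound 4 cannot be read: the limit of < 100000 nM in this assay, at which 1 of the 4 values shown sits.

Both readable steps change the bridging atom and the ring substituents together, so the contribution of oxygen versus sulfur alone stays unresolved. As far as these compounds go, how an amine or a carboxylic acid on the outer aromatic ring would affect growth inhibition also remains open.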